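Piperidinyl to Pyrrolidinyl on the Thiocarbonyl Carbon

The source may hold more compounds than are shown below. What is called first, only, known or untested is meant among the compounds shown, and "the series" means these compounds.

Compound 1, `O=C(/C=C/c1ccc(Cl)cc1)c1ccc(OCCSC(=S)N2CCOCC2)cc1`, in a functional assay on ECa-109 cells for inhibition, with ECa-109 cell line (Homo sapiens) as the target, read by MTT assay, with a stated time of 72 h; on this read-out higher numbers stand for weaker inhibition and lower numbers for stronger inhibition: 15400 nM
Compound 2, `O=C(/C=C/c1ccc(Cl)cc1)c1ccc(OCCSC(=S)N2CCCCC2)cc1`, in this assay: 26100 nM
Compound 3, `COc1ccc(/C=C/C(=O)c2ccc(OCCCSC(=S)N3CCN(C)CC3)cc2)cc1`, in this assay: > 100000 nM, which is a limit of the assay and not a number.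

Compound 2 holds the highest of the two numbers; its nearest neighbour is compound 1, and the step of a 1.7-fold higher number from compound 1 to compound 2 (0.23 log units; within the scatter) lies within the scatter. Compound 4, `O=C(/C=C/c1ccc(Cl)cc1)c1ccc(OCCSC(=S)N2CCCC2)cc1`, differs from compound 2 by pyrrolidin-1-yl in place of piperidin-1-yl on a thiocarbonyl carbon. Among the measured compounds shown here, the only measured step that bears on this change is a 1.7-fold higher number from compound 1 to compound 2 (0.23 log units; within the scatter), which also exchanged one ring on the thiocarbonyl carbon for another and stayed within the scatter. In this assay no step beyond the scatter is therefore expected from compound 2 to compound 4, that is a 1.1-fold lower number from compound 2 to compound 4 (0.04 log units; within the scatter). Compound 4 is estimated at 24000 nM, between 9000 nM and 65000 nM.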

Compound 4, half-maximal inhibitory concentration: 27800 nM
Compound 4: the middle estimate sits 1.2-fold (0.06 log units) below what was measured, and the stated range covers the measured number.
By their numbers in this assay, from the lowest: compounds 1, 2 and 4 (each within the scatter of the next). At a limit, above all of these: compound 3.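

In this assay, the group on the thiocarbonyl carbon changes from a six-membered to a five-membered ring with no step beyond the scatter: a 1.1-fold higher number from compound 2 to compound 4 (0.03 log units; within the scatter). The step that spans the whole set of rings also stays within the scatter: a 1.8-fold higher number from compound 1 to compound 4 (0.26 log units; within the scatter). So morpholin-4-yl, piperidin-1-yl and pyrrolidin-1-yl read alike at this place in compound 1, compound 2 and compound 4, and nothing shown gives a cause for this.

On these data alone, whether a diethylamino group, which carries no ring, or the larger azepan-1-yl on this carbon would read the same stays open.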